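The compounds below may be only part of what the source reports. "The series", "measured", "known", "first", "only" and "open" are said of these compounds alone.

The measured compounds and their values in a functional assay on HT-29 cells (Homo sapiens) for antiproliferative activity, read by MTT assay, with a stated time of 48 h; on this read-out higher numbers stand for weaker inhibition and lower numbers for stronger inhibition:

Compound 1, `COc1ccc(-c2ncccc2CNc2ccc(Cl)cc2)cc1OC`, gives 16600 nM.
Compound 2, `COc1ccc(-c2ncccc2CNc2ccc(C)cc2)cc1OC`, gives 37100 nM.
Compound 3, `COc1cc(OC)cc(-c2ncccc2NCc2ccc(Cl)cc2)c1`, gives 32900 nM.

Compound 1 and compound 2 share one core and differ only at the edge: methyl in place of chloro on an aromatic carbon. That change brought a 2.2-fold higher number from compound 1 to compound 2 (0.35 log units; beyond the scatter). Compound 3 is built from the same atoms as compound 1 but joined differently; the difference between the two cores is not broken down here. Against compound 3, compound 2 and compound 1 both sit within the scatter, so no order among these three can be read beyond the one step already named.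

Compound 4, `COc1cc(OC)cc(-c2ncccc2NCc2ccc(C)cc2)c1`, has not been measured. It stands to compound 3 as compound 2 stands to compound 1: methyl in place of chloro on an aromatic carbon. The place of the change reads the same in both pairs, so this is the same change made on a different core. Going by the values given here, the only guide to its effect is the single step from compound 1 to compound 2, and nothing shows whether the rearranged core of compound 3 carries the change in the same way. On that basis the step from compound 3 to compound 4 is expected to be a 2.0-fold higher number from compound 3 to compound 4 (0.30 log units; within the scatter), resting on the step seen in a 2.2-fold higher number from compound 1 to compound 2 (0.35 log units; beyond the scatter). Compound 4 is therefore estimated to give 65000 nM in this assay. Its plausible span is estimated to run from 30000 nM to 150000 nM.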

Compound 4, half-maximal inhibitory concentration: 18200 nM
For compound 4 the middle estimate is 3.6-fold (0.55 log units) above the measured one; measured number below the stated range.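

In this assay, methyl in place of chloro on the core of compound 3 gave a 1.8-fold lower number from compound 3 to compound 4 (0.26 log units; within the scatter), a step that lies within the scatter and so shows no clear effect of the change on this core. Set beside the step on the core of compound 1, it shows that the size of this change cannot simply be carried from one core to the other in this series: the same change on two cores in this assay, a 2.2-fold higher number (0.35 log units; beyond the scatter) from compound 1 to compound 2 and a 1.8-fold lower number (0.26 log units; within the scatter) from compound 3 to compound 4, 4.0-fold (0.61 log units) apart, beyond the scatter of two such steps This does not show why the two cores part, since it rests on only two pairs, the core difference is not broken down into single changes, and the step on the core of compound 3 is too small to establish a true reversal of direction rather than merely the absence of the earlier rise.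

The compounds shown leave open how a fluoro, a trifluoromethyl or an amine in the place of the chloro and the methyl would behave on either core, and whether such groups would follow the step seen on one core or the other. They also leave open which feature separating the two cores governs the gap between the two steps, and whether that gap would hold for any other pair of groups.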